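The source may report more compounds than this note shows. Statements on the series, on what has been measured and on what is new or still open speak of the compounds shown alone.

Measured so far in a functional assay on SMMC-7721 cells (Homo sapiens) for antiproliferative activity, read by MTT assay, with a stated time of 48 h; a lower number here means a stronger inhibitor, a higher number a weaker inhibitor:
- compound 1 `CC(=O)OC/C1=C/C[C@](C)(CCC=C(C)C)/C=C/[C@@H](OC(=O)C=C(C)C)[C@](C)(O)/C=C/C1=O`: 2950 nM
- compound 2 `CC(C)=CCC[C@]1(C)/C=C/[C@@H](OC(=O)C=C(C)C)[C@](C)(O)/C=C/C(=O)/C(C(=O)O)=C\C1`: > 10000 nM, a limit of the assay
- compound 3 `CC(C)=CCC[C@]1(C)/C=C/[C@@H](OC(=O)C=C(C)C)[C@](C)(O)/C=C/C(=O)/C(C[Si](C)(C)C(C)(C)C)=C\C1`: 4000 nM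

Compound 3 lies within the scatter of compound 1, as shown by a 1.4-fold higher number from compound 1 to compound 3 (0.13 log units; within the scatter). Compound 2 gives no number, only a limit.

Compound 4 `CC(C)=CCC[C@]1(C)/C=C/[C@@H](OC(=O)C=C(C)C)[C@](C)(O)/C=C/C(=O)/C(CN=[N+]=[N-])=C\C1` is next, with this change from compound 3: a group of 3 heavy atoms (3 nitrogen; no ring) in place of a group of 7 heavy atoms (6 carbon, 1 silicon; no ring), on a saturated chain carbon bound to a double-bonded ring carbon. Among the compounds with values here, the closest precedent is the swap between compound 1 and compound 3 on a saturated chain carbon bound to a double-bonded ring carbon, a 1.4-fold higher number from compound 1 to compound 3 (0.13 log units; within the scatter). Two very different groups at that place therefore gave values within the scatter. The larger steps, an at least 3.3-fold higher number from compound 1 to compound 2 (0.53 log units; beyond the scatter) and an at least 2.5-fold lower number from compound 2 to compound 3 (0.39 log units; beyond the scatter), both involve carboxy directly on a double-bonded ring carbon, so they bear less on this change. In this assay, the expected result is a 1.3-fold lower number from compound 3 to compound 4 (0.10 log units; within the scatter), which means no change beyond the scatter. The estimated value for compound 4 is 3200 nM, with an expected range of 1300 nM to 8000 nM.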

Compound 4, half-maximal inhibitory concentration: 3080 nM
Beside the measured number, compound 4's estimate is 1.0-fold (0.02 log units) above it; the range from low to high includes it.
By their numbers in this assay, from the lowest: compounds 1, 4 and 3 (each within the scatter of the next). At a limit, above all of these: compound 2.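

In this assay, azido on a saturated chain carbon bound to a double-bonded ring carbon stays within the scatter of both earlier groups at that place, with a 1.3-fold lower number from compound 3 to compound 4 (0.11 log units; within the scatter) and a 1.0-fold higher number from compound 1 to compound 4 (0.02 log units; within the scatter), so acetoxy, the silicon-bearing group of compound 3 and azido now give no step beyond the scatter among compounds 1, 3 and 4. Compound 2 goes against this flat picture, but it carries carboxy directly on the double-bonded ring carbon, and azidomethyl in its place gives an at least 3.2-fold lower number from compound 2 to compound 4 (0.51 log units; beyond the scatter). The value of compound 2 is a limit, not a number: the limit of > 10000 nM in this assay, at which 1 of the 4 values shown sits.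

From the compounds shown here alone, whether that limit belongs to the carboxy group itself or to the absence of the saturated chain carbon stays open. A carboxylic acid or an amine carried on that saturated chain carbon would separate the two.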